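Azetidine-oxadiazole series: replacing the cyclobutyl amide with a urea

The source may hold more compounds than are shown below. What is called first, only, known or untested is meant among the compounds shown, and "the series" means these compounds.

Two compounds of this series have numbers in an assay on HEK293 cells for negative allosteric modulation of metabotropic glutamate receptor 5 (Homo sapiens), read by FLIPR (on this read-out higher numbers stand for weaker inhibition and lower numbers for stronger inhibition), so far. Compound 1 `O=C(c1ccccc1F)N1CC[C@H]1c1nc(-c2cccc(F)c2)no1` gives 920 nM in this assay. Compound 2 `O=C(C1CCC1)N1CC(c2nc(-c3cccc(Cl)c3)no2)C1` gives 1500 nM in this assay. The two numbers lie within the usual scatter of each other, so nothing separates compound 2 from compound 1 on this read-out; no pair of measured compounds differing in a single place is available, and no step beyond the scatter has been shown within the series.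

Compound 3 `CC1CN(C(=O)N2CC(c3nc(-c4cccc(Cl)c4)no3)C2)CC(C)O1` is the next compound to be measured. It differs from compound 2 in one place: 2,6-dimethylmorpholin-4-yl in place of cyclobutyl on a carbonyl carbon. Among the compounds with values here, with no measured step to lean on, the expectation for the move from compound 2 to compound 3 is a small one, a modest weakening at most, and most likely nothing beyond the scatter; the estimated step is a 1.3-fold higher number from compound 2 to compound 3 (0.12 log units; within the scatter). Compound 3 is therefore expected to give about 2000 nM in this assay, with a range from 700 nM to 6000 nM.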

Compound 3, half-maximal inhibitory concentration: 990 nM
For compound 3 the middle estimate is 2.0-fold (0.31 log units) above the measured one, and the stated range covers the measured number.
By their numbers in this assay, from the lowest: compounds 1, 3 and 2 (each within the scatter of the next).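

In this assay the carbonyl carbon bearing the amide-type nitrogen in a ring now has its first measured single-place change: 2,6-dimethylmorpholin-4-yl in place of cyclobutyl gives a 1.5-fold lower number from compound 2 to compound 3 (0.18 log units; within the scatter), so this place accepts a group of 8 heavy atoms in place of 4, with a ring oxygen and two methyl groups, without a step beyond the scatter. On this read-out the urea of compound 3 and the cyclobutyl amide of compound 2 cannot be told apart, a statement that rests on this single pair. Nothing available explains the outcome of this change.

Going by these compounds, whether the same holds for other groups at this place remains open: unsubstituted morpholin-4-yl would separate the ring oxygen from the two methyl groups, while piperidin-1-yl or an open-chain dimethylamino urea would test the need for the oxygen and for the ring. Also open, on these data alone, is whether the change would give a similar step on the core of compound 1, which differs from compound 2 in more than one place.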